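The compounds below may be only part of what the source reports. "The series", "measured", "known", "first", "only" and "open" are said of these compounds alone.

Working notes on the series. In a functional assay on A549 cells (Homo sapiens) for antiproliferative activity, read by sulforhodamine B assay, with a stated time of 72 h (on this read-out higher numbers stand for weaker inhibition and lower numbers for stronger inhibition), compound 1 `COc1ccc(/C=C2\CCC=CC2=O)cc1OC` gives 4680 nM. In this assay compound 2 `COc1cc(/C=C2\CCC=CC2=O)cc(OC)c1` gives 4740 nM, and the two values lie within the scatter of each other. Compound 2 therefore stands level with compound 1, and the pair cannot be ranked. Among the measured compounds shown here, these are the only two numbers so far, and they share the core and differ in the pattern of their methoxy groups.

Compound 3 `COc1cc(/C=C2\CCC=CC2=O)cc(OC)c1OC` comes from compound 2 by methoxy in place of hydrogen on an aromatic carbon, with methoxy in place of hydrogen on an aromatic carbon. For the measured compounds named here, no measured pair shows what such a replacement does, so any expectation here is weakly supported. Going by the values given here, the only guide is that the different methoxy pattern of compound 1 still leaves it level with compound 2 at 4740 nM, so a large step is not expected. A small move towards stronger inhibition in this assay is expected, possibly not beyond the scatter. The expected change is a 1.4-fold lower number from compound 2 to compound 3 (0.13 log units; within the scatter). For compound 3 the estimated value is 3500 nM, with an expected range of 1400 nM to 7500 nM.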

Compound 3, half-maximal inhibitory concentration: 4250 nM
For compound 3 the middle estimate is 1.2-fold (0.08 log units) below the measured one; low and high end bracket the measured number.
By their numbers in this assay, from the lowest: compounds 3, 1 and 2 (each within the scatter of the next).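

In this assay, among the compounds shown here, methoxy in place of hydrogen on the aromatic carbon ortho to two methoxy groups and para to a group of 8 heavy atoms gives a 1.1-fold lower number from compound 2 to compound 3 (0.05 log units; within the scatter), so at this position the added methoxy group produces no step that leaves the scatter. Read from the other methoxy pattern, the same kind of replacement gives a 1.1-fold lower number from compound 1 to compound 3 (0.04 log units; within the scatter), also within the scatter, so the three methoxy groups of compound 3 stand level with the two of either compound 1 or compound 2 and the number of methoxy groups does not separate these compounds. No measurement at hand bears on the reason for this flat result.

From the compounds shown here alone, whether a different group at this position, such as an amine, a hydroxyl or a carboxylic acid, would give a step beyond the scatter remains open. All the compounds shown carry only methoxy groups on the shared core, so it also remains open whether any change elsewhere in that core would separate them in this assay.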